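A few compounds are considered here, and "the series" means these few. Any claim that something is new, unique, unknown or untested is made for them only; others in the source may bear on it.

In an ADME assay on microsomes from liver (Homo sapiens) for metabolic stability, with a stated time of 10 min (a lower number here means that less of the compound is left, a higher number that more of the compound is left), compound 1 `COc1cc(OCc2cccc(COc3ccccc3)c2)c2cc(-c3cn4nc(OC)sc4n3)oc2c1` gives 86%. Among the three compounds measured so far it stands near the top: compound 2 `COc1nn2cc(-c3cc4ccc(OCc5ccccc5)cc4o3)nc2s1` gives 94%, a number within the usual scatter of that of compound 1, so the two cannot be told apart, while compound 3 `COc1ccc2oc(-c3cn4nc(OC)sc4n3)cc2c1` gives 30%, far below compound 1 and beyond the scatter. The two compounds carrying a large group on the shared core thus both show much remaining compound, and the one without it shows little.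

Compound 4 `COc1cc(OCc2cccc(OCc3ccccc3)c2)c2cc(-c3cn4nc(OC)sc4n3)oc2c1` has the same atoms as compound 1 joined differently: benzyloxy in place of phenoxymethyl on an aromatic carbon. For the measured compounds named here, no measured pair shows this kind of change, so its effect is unknown here. Since a large group of the same size and composition remains in place, compound 4 is expected to behave much as compound 1 does, and the step of a number 6 percentage points lower from compound 1 to compound 4 (within the scatter) is estimated to be small, if anything slightly downward, and not beyond the scatter. For compound 4 in this assay the estimate is 80%, with a range from 60% to 95%.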

Compound 4, percent of the compound remaining: 85%
Beside the measured number, compound 4's estimate is 5 percentage points below it; the range from low to high includes it.
By their numbers in this assay, from the lowest: compound 3; then compounds 4, 1 and 2 (each within the scatter of the next).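

In this assay, for the compounds shown here, benzyloxy in place of phenoxymethyl on an aromatic carbon, meta to a large group, gives a number 1 percentage points lower from compound 1 to compound 4 (within the scatter), the first step that can be read at this position. Joining the same atoms differently at this place therefore leaves the two compounds indistinguishable in this read-out, which the earlier compounds, none differing from another in one place, could not show. No other measurement is at hand that could explain this result.

This pair speaks only to an exchange between two groups with the same atoms, each carrying one six-membered aromatic ring of carbon only. On these data alone, whether an amine, a carboxylic acid or a longer chain at this place would leave the number where it stands remains open.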